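Notes on removing the benzyloxy group from compound 1

This account rests on a few compounds, and the source may have more. Where it says the series, first, only, none or still open, it means among the compounds named here.

Of the compounds shown here, three of the shared core have numbers so far in an assay for inhibition of Indoleamine 2,3-dioxygenase 1 (Homo sapiens), with stated times of 10 min and 60 min, tested at 10 uM; a lower number here means a weaker effect, a higher number a stronger effect of the compound at the concentration tested. Compound 1 `O=[N+]([O-])c1cc(OCc2ccccc2)ccc1CNc1cc(C(F)(F)F)cc2[nH]ncc12` gives 10% in this assay, the lowest of the three numbers. Compound 3 `FC(F)(F)c1cc(NC[C@H]2CCCCN2)c2cn[nH]c2c1` gives 19% in this assay, a number within the scatter of compound 1. Compound 2 `O=[N+]([O-])c1ccc2[nH]c(CNc3cc(C(F)(F)F)cc4[nH]ncc34)cc2c1` gives 22% in this assay, a number that stands beyond the scatter above compound 1. Among the measured compounds shown here, all three numbers are small, and no pair of measured compounds differs in only one place, so no measured step is available.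

Compound 4 `O=[N+]([O-])c1ccccc1CNc1cc(C(F)(F)F)cc2[nH]ncc12` is not yet measured. It differs from compound 1 by hydrogen in place of benzyloxy on an aromatic carbon: the benzyloxy group leaves from an aromatic carbon of the six-membered aromatic ring of carbon only, meta to the nitro group and para to the large group, and hydrogen enters there. For the measured compounds named here, nothing among the measured compounds shows what this loss does in this assay. Going by the values given here, the only anchor is compound 1, which carries the benzyloxy group and gives 10% in this assay, the lowest number seen.

The expected step is a number 2 percentage points lower from compound 1 to compound 4 (within the scatter), none beyond the scatter, since the starting number is already low. Compound 4 is accordingly estimated at 8% in this assay, within a range from -6% to 22%.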

Compound 4, a percentage reported as inhibition, at one concentration (the size of the read-out at that concentration, not a potency): 35%
Compound 4: middle estimate off by 27 percentage points, on the low side, and the stated range ends below it.
By their numbers in this assay, from the lowest: compounds 1, 3 and 2 (each within the scatter of the next, the first and the last beyond it); then compound 4.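

Hydrogen in place of benzyloxy on an aromatic carbon, meta to a nitro group and para to a large group, gives in this assay the first measured step of the series, a number 25 percentage points higher from compound 1 to compound 4 (beyond the scatter), and the change therefore registers at this position. The benzyloxy group, with its six-membered aromatic ring of carbon only, is thus not required for the read-out at the concentration tested, and in this single pair its presence goes with the lower number. No available measurement accounts for this step, so its cause remains unassigned.

The compounds shown leave open whether the step follows from losing the whole benzyloxy group or only part of it; a methoxy or hydroxyl group on the same carbon would divide the group into its oxygen and its benzyl portion, while an amine or a carboxylic acid there would test other replacements. They also leave open whether the same step would appear with a nitrile in place of the nitro group, since this one pair carries the nitro group on both sides.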